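Nitrooxy for bromo on the (bromomethyl)carbonyl group

The source may hold more compounds than are shown below. What is called first, only, known or untested is meant among the compounds shown, and "the series" means these compounds.

Compound 2 `O=C(CBr)Nc1ccc(C(=O)/C=C/c2ccc(Cl)cc2)cc1` is the reference for this step. In a functional assay on the whole organism (strain albino) for inhibition, with Rattus norvegicus as the target, read by paw edema, with stated times of 30 min and 5 h, at a dose of 100 mg/kg by the oral route (on this read-out lower numbers stand for less inhibition and higher numbers for more inhibition at the one dose given (going by the name of the read-out)), compound 2 gives 54%. Its parent, compound 1 `Nc1ccc(C(=O)/C=C/c2ccc(Cl)cc2)cc1`, gives 54% in this assay, and the step of no change at the digits printed from compound 1 to compound 2 (within the scatter) leaves compound 2 level with compound 1 at the digits shown, the two standing together at the top of the three numbers known. Compound 3 `O=C(CBr)Nc1ccc(C(=O)/C=C/c2ccco2)cc1` gives 25% in this assay; the step of a number 29 percentage points lower from compound 2 to compound 3 (beyond the scatter) is the only one beyond the scatter in the series, and it exchanges the 4-chlorophenyl, not anything on the (bromomethyl)carbonyl.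

Compound 4 `O=C(CO[N+](=O)[O-])Nc1ccc(C(=O)/C=C/c2ccc(Cl)cc2)cc1` differs from compound 2 as nitrooxy in place of bromo on a saturated chain carbon bound to a carbonyl carbon. Neither measured step exchanges the bromo itself: the step of no change at the digits printed from compound 1 to compound 2 (within the scatter) put the whole (bromomethyl)carbonyl onto the nitrogen without moving the number, and the step of a number 29 percentage points lower from compound 2 to compound 3 (beyond the scatter) left that group untouched. Among the compounds with values here, the one step that does bear on this group was flat, so for compound 4 a step of a number 4 percentage points lower from compound 2 to compound 4 (within the scatter) is expected, that is none beyond the scatter, with a wide range because no measured step replaces the bromo. Compound 4 is therefore estimated at 50% in this assay, within 33% to 65%.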

Compound 4, a percentage reported as inhibition, in the whole organism at one dose (the size of the read-out at that dose, not a potency): 60%
Beside the measured number, compound 4's estimate is 10 percentage points below it; the measured number falls inside the stated range.
By their numbers in this assay, from the lowest: compound 3; then compounds 1, 2 and 4 (each within the scatter of the next).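

In this assay, within the data shown here, the bromo itself is exchanged for the first time, and a number 6 percentage points higher from compound 2 to compound 4 (within the scatter) shows that this saturated chain carbon bound to a carbonyl carbon accepts nitrooxy, with 4 heavy atoms and 3 hydrogen-bond acceptors in place of a single bromine, without a step beyond the scatter. The whole ((nitrooxy)methyl)carbonyl group on the nitrogen reads the same way, with a number 6 percentage points higher from compound 1 to compound 4 (within the scatter) matching the flat result for the (bromomethyl)carbonyl group, so at this dose neither group separates from the hydrogen of compound 1. No measurement at hand accounts for the read-out holding across these exchanges.

Still open, going by these compounds, is whether a hydroxy or a dimethylamino group in place of bromo, or a longer chain carrying the nitrooxy, would also stay within the scatter of compound 2. Also open, on these data alone, is whether nitrooxy in place of bromo holds up with furan-2-yl in place of 4-chlorophenyl, and whether these single-dose numbers would still read level at other doses.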